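A few compounds are considered here, and "the series" means these few. Any claim that something is new, unique, unknown or untested is made for them only; others in the source may bear on it.

Compound 1 `CC(C)NC(=O)N1CCN(C(=S)SCc2cn(Cc3ccc(F)cc3)nn2)CC1` and compound 2 `CCN(C)C(=O)N1CCN(C(=S)SCc2cn(Cc3ccc(F)cc3)nn2)CC1` share one core and differ in a single place: ethyl(methyl)amino in place of isopropylamino on a carbonyl carbon. In a functional assay on MCF7 cells (Homo sapiens) for cytotoxicity, read by MTT assay, with a stated time of 72 h (a lower number here means a stronger inhibitor, a higher number a weaker inhibitor), compound 1 gives 1660 nM. In this assay compound 2 gives 2150 nM. The step of a 1.3-fold higher number from compound 1 to compound 2 (0.11 log units; within the scatter) shows the two values sitting within the scatter of each other, so neither can be called the stronger.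

Compound 3 `COc1cc(Cn2cc(CSC(=S)N3CCN(C(=O)NC(C)C)CC3)nn2)cc(OC)c1OC` rests on another core; the difference between the two cores is not broken down here. For compound 3 in this assay only a limit is reported, > 128000 nM, and this is the limit (the limit of > 128000 nM in this assay, at which 1 of the 3 values shown sits).

Compound 4 `CCN(C)C(=O)N1CCN(C(=S)SCc2cn(Cc3cc(OC)c(OC)c(OC)c3)nn2)CC1` has not yet been measured in this assay. It differs from compound 3 as ethyl(methyl)amino in place of isopropylamino on a carbonyl carbon, the same change that was made from compound 1 to compound 2, at the same place in the molecule. Since that earlier step stayed within the scatter, the step from compound 3 to compound 4 is expected to be small as well, about a step that the limit leaves unreadable from compound 3 to compound 4. Compound 4 is therefore estimated at 200000 nM, between 64000 nM and 600000 nM, most likely again reported only as a limit.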

Compound 4, half-maximal inhibitory concentration: 68500 nM
Estimate against measurement, compound 4: 2.9-fold (0.47 log units) above; measured number inside the range.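

Carried to the core of compound 3, the change from isopropylamino to ethyl(methyl)amino gives an at least 1.8-fold lower number from compound 3 to compound 4 (0.27 log units; that floor lies within the scatter) in this assay. For compound 3, the reported > 128000 nM is a limit of the assay and not a number, so this step has only a floor. The data therefore show neither that the change carries over unaltered from one core to the other nor that it acts differently on them, since the full size of the second step stays unknown: the same change on two cores in this assay, a 1.3-fold higher number (0.11 log units; within the scatter) from compound 1 to compound 2 and an at least 1.8-fold lower number (0.27 log units; that floor lies within the scatter) from compound 3 to compound 4; the limit leaves it open whether they differ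

The compounds shown hold only these two groups on the carbonyl carbon, so they leave open how a longer chain such as butylamino or a ring amine such as pyrrolidine would read in that place on either core. They also leave open whether the small step between compound 1 and compound 2 would hold on any further core.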